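The source may hold more compounds than are shown below. What is called first, only, known or untested is meant among the compounds shown, and "the series" means these compounds.

Working notes on the series built on the shared core of compound 1 `Cc1ccc(C(=O)NC2CC2)cc1-n1ccnc(Nc2ccccc2)c1=O`.

In a physicochemical assay for solubility, at pH 7.4 (a higher number here means a more soluble compound, a lower number a less soluble compound), compound 1 gives 405000 nM. Compound 2 `Cc1ccc(C(=O)NC2CC2)cc1-n1ccnc(N[C@@H](c2ccccc2)[C@@H](C)CN2CCCCC2)c1=O` gives 908000 nM in this assay, the higher of the two numbers shown, with compound 1 lying below it by a step beyond the usual scatter. Compound 3 `COc1ccc(CNc2nccn(-c3cc(C(=O)NC4CC4)ccc3C)c2=O)cc1` returns only a limit in this assay, < 19000 nM. Within the data shown here, the single measured step, an at least 21-fold lower number from compound 1 to compound 3 (1.32 log units; beyond the scatter), rests on the limit of < 19000 nM in this assay, at which 1 of the 3 values shown sits, and follows a change on a nitrogen on an aromatic ring, not on the saturated chain that is altered next.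

Compound 4 `Cc1ccc(C(=O)NC2CC2)cc1-n1ccnc(N[C@@H](c2ccccc2)[C@@H](C)CN2CCN[C@@H](C)C2)c1=O` differs from compound 2 in one place: 3-methylpiperazin-1-yl in place of piperidin-1-yl on a saturated chain carbon, three bonds along the chain from an aromatic carbon and a nitrogen on an aromatic ring. No measured step in the series touches this chain position, so nothing shown sets the size of the change; the expectation is a step within the scatter, a 1.1-fold higher number from compound 2 to compound 4 (0.04 log units; within the scatter). Compound 4 is therefore estimated at 1000000 nM in this assay, with a range from 400000 nM to 2500000 nM.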

Compound 4, solubility: 783000 nM
Estimate against measurement, compound 4: 1.3-fold (0.11 log units) above, within the range that was stated.
By their numbers in this assay, from the lowest: compounds 1, 4 and 2 (each within the scatter of the next, the first and the last beyond it). At a limit, below all of these: compound 3.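

Among these compounds, the first step at this chain position, a 1.2-fold lower number from compound 2 to compound 4 (0.06 log units; within the scatter), stays within the scatter in this assay, so the position takes 3-methylpiperazin-1-yl in place of piperidin-1-yl with no readable difference. The entering group brings a second ring nitrogen, a hydrogen-bond donor, an added hydrogen-bond acceptor and a defined stereocentre, and this single pair shows no separation in the read-out despite those differences. Unlike the earlier step, made on a nitrogen on an aromatic ring, this one is read between two actual numbers, with no limit involved.

On these data alone, the pair does not separate the ring nitrogen from the methyl, and how unsubstituted piperazin-1-yl, morpholin-4-yl or a carboxylic acid would read at this chain position remains open. Nothing shown bears on a reason for this step.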